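A few compounds are considered here, and "the series" means these few. Any claim that something is new, unique, unknown or untested is made for them only; others in the source may bear on it.

In a functional assay on RS4-11 cells (Homo sapiens) for inhibition, read by CCK-8 assay, with a stated time of 48 h, tested at 20 uM (a lower number here means less inhibition of growth, a higher number more inhibition of growth at the concentration tested), compound 1 (`COc1ccc(Cc2nnc(NC(=O)/C(C#N)=C/c3ccccc3OS(=O)(=O)c3ccc(C)cc3)s2)cc1`) gives 70% and compound 2 (`COc1ccc(Cc2nnc(NC(=O)/C(C#N)=C/c3ccccc3OS(=O)(=O)c3ccc(OC)cc3)s2)cc1`) gives 78%, so these two stand level within the scatter. Compound 3 (`COc1ccc(S(=O)(=O)Oc2ccccc2/C=C(\C#N)C(=O)Nc2nnc(Cc3ccc(Cl)cc3)s2)cc1`) alters compound 2 in one place, with chloro in place of methoxy on an aromatic carbon. Among the compounds with values here, the only measured step (a number 8 percentage points higher from compound 1 to compound 2 (within the scatter)) stayed within the scatter and changed a different aromatic carbon, so it offers weak guidance, and no change beyond the scatter is expected. The estimated step (a number 2 percentage points lower from compound 2 to compound 3 (within the scatter)) is therefore small. The estimated value for compound 3 is 76% (range 62% to 90%).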

Compound 3, percent growth inhibition at one concentration: 77%
Compound 3: the middle estimate sits 1 percentage points below what was measured, and the stated range covers the measured number.
By their numbers in this assay, from the lowest: compounds 1, 3 and 2 (each within the scatter of the next).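

Changing the 4-methoxybenzyl group to 4-chlorobenzyl gives a number 1 percentage points lower from compound 2 to compound 3 (within the scatter) in this assay. This is the first change shown on this aromatic ring, which stayed the same between compound 1 and compound 2, and here chloro can replace methoxy without a readable change in growth inhibition at the concentration tested. Nothing available explains why the two groups read alike. On these data alone, whether an amine or a carboxylic acid at this place would also hold the number stays open. So does whether compound 2 and compound 3 would still read alike at lower concentrations.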